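From (4-methylphenyl)amino to 4-methylpiperidin-1-yl in compound 1

This account rests on a few compounds, and the source may have more. Where it says the series, first, only, none or still open, it means among the compounds named here.

Among the compounds with values here, in a functional assay on NCI-H460 cells (Homo sapiens) for antiproliferative activity, read by CCK-8 assay, with a stated time of 72 h (on this read-out higher numbers stand for weaker inhibition and lower numbers for stronger inhibition), compound 1 `Cc1ccc(Nc2nc(Cl)nc3c2ncn3Cc2ccc(C(=O)Nc3ccccc3N)cc2)cc1` gives 1590 nM, the lowest of the three numbers so far. Compound 3 `CCCCn1cnc2c(Nc3ccccc3)nc(NCOCc3ccc(C(=O)Nc4ccccc4N)cc3)nc21` gives 8780 nM and compound 2 `Nc1ccccc1NC(=O)c1ccc(Cn2cnc3c(Nc4ccc(-c5ccccn5)cc4)nc(Cl)nc32)cc1` gives 18400 nM, both beyond the scatter from compound 1.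

Compound 4 `CC1CCN(c2nc(Cl)nc3c2ncn3Cc2ccc(C(=O)Nc3ccccc3N)cc2)CC1` has not yet been measured. It keeps the core of compound 1 and changes one group, on an aromatic carbon meta to a chloro group: 4-methylpiperidin-1-yl in place of (4-methylphenyl)amino on an aromatic carbon.

Within the data shown here, only one measured step touches this group: a 12-fold higher number from compound 1 to compound 2 (1.06 log units; beyond the scatter), with pyridin-2-yl in place of methyl on an aromatic carbon. Among the measured compounds shown here, that large step shows the number can rise with a change inside the group, but no measured compound replaces the whole group, so it is only a loose guide. A moderate rise is expected, smaller than that step, and the estimated step is a 2.5-fold higher number from compound 1 to compound 4 (0.40 log units; beyond the scatter). Compound 4 is estimated at 4000 nM, with an expected range of 1300 nM to 13000 nM.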

Compound 4, half-maximal inhibitory concentration: 7400 nM
Beside the measured number, compound 4's estimate is 1.9-fold (0.27 log units) below it; the measured number falls inside the stated range.
By their numbers in this assay, from the lowest: compound 1; then compounds 4 and 3 (each within the scatter of the next); then compound 2.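

In this assay, the whole (4-methylphenyl)amino group can be replaced on this aromatic carbon next to the ring nitrogen, with a 4.7-fold higher number from compound 1 to compound 4 (0.67 log units; beyond the scatter) as the cost. The earlier step from compound 1 changed only a substituent within that group, whereas this change swaps the six-membered aromatic ring of carbon for a non-aromatic ring with a hetero atom and removes the hydrogen-bond donor. Compound 4 therefore shows that neither the aromatic ring nor the donor is strictly required for a measurable number in this series, but no measurement on hand gives a reason for the rise.

The contributions of the ring and the donor remain unseparated. A cyclohexylamino group would keep the amine hydrogen on a non-aromatic ring, and an unsubstituted piperidin-1-yl would address the role of the methyl group.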